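Phenylpropanoid diacetates: removing the allyl ether

The compounds below may be only part of what the source reports. "The series", "measured", "known", "first", "only" and "open" are said of these compounds alone.

Two measured compounds are in hand. Compound 1 `CC(=O)OC/C=C/c1ccc(OCc2ccccc2)c(O)c1` gives 13000 nM in a functional assay on HeLa cells (Homo sapiens) for inhibition, read by MTT assay, with a stated time of 48 h; on this read-out lower numbers stand for stronger inhibition and higher numbers for weaker inhibition. Compound 2 `C=CCOc1ccc(CC(COC(C)=O)OC(C)=O)cc1OC` gives 96000 nM in this assay, the highest of the two numbers, with compound 1 the nearest at a markedly lower number, a gap beyond the scatter. The two structures differ in several places at once, so nothing is drawn from that pair beyond what the two values show.

The step under consideration leads from compound 2 to compound 3 `COc1cc(CC(COC(C)=O)OC(C)=O)ccc1O`, a change of hydrogen in place of allyl on an oxygen on an aromatic ring. Within the data shown here, no measured pair in this small set shows this change, so its effect on this assay is not known from the series. Among the measured compounds shown here, with only two numbers and no comparable step, the expectation is a small shift, not clearly beyond the scatter, expressed as a 1.6-fold lower number from compound 2 to compound 3 (0.20 log units; within the scatter). Compound 3 is thus estimated at 60000 nM in this assay, within a range of 20000 nM to 200000 nM.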

Compound 3, half-maximal inhibitory concentration: 60000 nM
For compound 3 middle estimate and measured number coincide at the digits printed; measured number inside the range.
By their numbers in this assay, from the lowest: compound 1; then compounds 3 and 2 (each within the scatter of the next).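

Hydrogen in place of allyl on an oxygen on an aromatic ring is the first single-place change available in the series, and in this assay it reads as a 1.6-fold lower number from compound 2 to compound 3 (0.20 log units; within the scatter). At this oxygen, then, allyloxy and hydroxy are not told apart by this read-out, and the allyl group with its double bond is not needed to hold the number where it stands in compound 2. The weak numbers of both compounds stay as they are, and no measurement at hand speaks to why this change has so little effect.

Going by these compounds, whether a longer alkyl chain or an aminoethyl group on this oxygen would move the number beyond the scatter remains open. Also open, on these data alone, is how the two acetate esters bear on the number, for instance with a carboxylic acid in place of one of them.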